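Removing one methyl group on a ring oxygen

The compounds below may be only part of what the source reports. "The series", "measured", "known", "first", "only" and "open" are said of these compounds alone.

Measured so far:
compound 1, `COc1cc(/C=N/NC(=O)c2ccncc2)cc(OC)c1O`, 48%
compound 2, `COc1cc(/C=N/Nc2nc3ccccc3s2)cc(OC)c1O`, 36%
compound 3, `COc1cc(/C=N/Nc2nc3ccccc3s2)cc(OC)c1OC`, 100%

In a physicochemical assay on cells (Homo sapiens), with a stated time of 18 h, tested at 1 uM (a lower number here means a stronger effect, a higher number a weaker effect of the compound at the concentration tested), compound 3 gives 100%. Compound 2 differs from compound 3 by hydrogen in place of methyl on an oxygen on an aromatic ring, and this single change produces a number 64 percentage points lower from compound 3 to compound 2 (beyond the scatter). Compound 1 has a different core from compound 3; the difference between the two cores is not broken down here. Compound 1 gives 48%, and compound 2 gives 36%, so compound 1 stands between the other two measured compounds.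

Compound 4, `COc1cc(/C=N/NC(=O)c2ccncc2)cc(O)c1O`, has not yet been measured. It differs from compound 1 by hydrogen in place of methyl on an oxygen on an aromatic ring, the same change that turns compound 3 into compound 2, at a place described in the same words. Because compound 3 to compound 2 showed a number 64 percentage points lower from compound 3 to compound 2 (beyond the scatter), a lower number is expected for compound 4 as well. Going by the values given here, the step is expected to be smaller, however, since compound 1 already starts at 48% and the read-out cannot fall far below zero, and since only a single example of this change is available, on a different core. The estimated step is a number 20 percentage points lower from compound 1 to compound 4 (beyond the scatter). Compound 4 is therefore expected to give about 28% in this assay, with a plausible range from 8% to 50%.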

Compound 4, a percentage reported as activity, at one concentration (the size of the read-out at that concentration, not a potency): 59%
The estimate for compound 4 lay 31 percentage points below the measured number; the measured number lies above the stated range.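

In this assay, the change from methoxy to hydroxy gives a number 11 percentage points higher from compound 1 to compound 4 (beyond the scatter), whereas the change described in the same words gives a number 64 percentage points lower from compound 3 to compound 2 (beyond the scatter), so in these two pairs its direction does not carry over from one core to the other. Going by these compounds alone, this does not show which direction is more usual, and with only two pairs it does not separate the effect of the core from the fact that compound 1 already carries a hydroxy group, while compound 3 carries none. No measurement shown here explains why the two steps point in opposite directions.

The compounds shown leave open what the same change would do on the core of compound 2, where a further methoxy group could become hydroxy, which would test whether the reversal follows the core or the hydroxy group already present. They also leave open how the read-out would respond to other groups on the ring, such as an ethoxy group, a longer chain on the oxygen, or an amine in place of the hydroxy group.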